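Swapping a side chain on a bis-aziridinyl quinone core

This account rests on a few compounds, and the source may have more. Where it says the series, first, only, none or still open, it means among the compounds named here.

Measured compounds:
- compound 1, `CC1=C(N2CC2)C(=O)C(Cc2ccccc2)=C(N2CC2)C1=O`, 4.74
- compound 2, `CC1=C(N2CC2)C(=O)C(C(C)C)=C(N2CC2)C1=O`, 4.96
- compound 3, `CC1=C(N2CC2)C(=O)C(CCC(=O)N(C)C)=C(N2CC2)C1=O`, 5.09

All three were tested in a functional assay on L1210 cells (Mus musculus), with a stated time of 1 days; on this read-out lower numbers stand for lower potency and higher numbers for higher potency (the scale is a negative logarithm). Compound 3 gives the highest of the three numbers: its gap to compound 2, a number 0.13 log units higher from compound 2 to compound 3 (within the scatter), is within the scatter, while its gap to compound 1, a number 0.35 log units higher from compound 1 to compound 3 (beyond the scatter), is modest but beyond it. Compound 4, `CC(=O)C1=C(N2CC2)C(=O)C(C)=C(N2CC2)C1=O`, is not yet measured. It differs from compound 3 in one place: acetyl in place of 2-(dimethylcarbamoyl)ethyl on a double-bonded ring carbon.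

The measured steps that bear on this are the swaps at the same ring position: a number 0.22 log units higher from compound 1 to compound 2 (within the scatter) and a number 0.13 log units higher from compound 2 to compound 3 (within the scatter), both within the scatter, and a number 0.35 log units higher from compound 1 to compound 3 (beyond the scatter), modest. Changing the group at this position has moved the numbers only a little across three quite different side chains, so a step of similar or smaller size is expected here, with no clear direction. The estimate for compound 4 is therefore 5, within 4.5 to 5.6, a step of a number 0.09 log units lower from compound 3 to compound 4 (within the scatter) that is expected to stay within the scatter.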

Compound 4, logarithm of the reciprocal of the active concentration, log(1/C): 3.94
Compound 4: the middle estimate sits 1.06 log units above what was measured; the measured number lies below the stated range.
By their numbers in this assay, from the lowest: compound 4; then compounds 1, 2 and 3 (each within the scatter of the next, the first and the last beyond it).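

In this assay, this double-bonded ring carbon proves less forgiving than the first three compounds suggested: with acetyl in place, the number falls, a number 1.15 log units lower from compound 3 to compound 4 (beyond the scatter) and a number 1.02 log units lower from compound 2 to compound 4 (beyond the scatter), both large, and a number 0.80 log units lower from compound 1 to compound 4 (beyond the scatter), modest. Each of these drops exceeds the widest step among the first three side chains, a number 0.35 log units higher from compound 1 to compound 3 (beyond the scatter), so benzyl, isopropyl and 2-(dimethylcarbamoyl)ethyl do not show how far a change here can move the number. No measurement shown explains the fall.

For the compounds shown here, only one compound carries acetyl, so it remains unknown whether the drop is particular to that group. A propionyl group, a carboxylic acid or an amine on this ring carbon would help show whether other groups fall as low as compound 4 or stay with the first three.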